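Compound 2 Gains a Pent-4-en-1-yl Chain

This account rests on a few compounds, and the source may have more. Where it says the series, first, only, none or still open, it means among the compounds named here.

In a functional assay on SK-MEL-28 cells (Homo sapiens) for inhibition, read by colorimetric assay and MTT assay, with a stated time of 72 h (on this read-out lower numbers stand for stronger inhibition and higher numbers for weaker inhibition), compound 2 `COc1ccccc1-c1cnc(OC)n1C` gives > 100000 nM, which is a limit of the assay and not a number. Compound 3 `C=CCCCCOc1ncc(-c2ccccc2OC)n1C` carries pent-4-en-1-yl in place of hydrogen on a saturated chain carbon bound to an oxygen on an aromatic ring. For the measured compounds named here, the only guide is compound 1 `CCCCCCOc1ncc(-c2ccccc2OC)n1C`, which has pentyl in that place and gives 43000 nM. Replacing that pentyl with hydrogen produced an at least 2.3-fold higher number from compound 1 to compound 2 (0.36 log units; beyond the scatter). Read in reverse, that step suggests a similar move towards lower numbers, beyond the scatter. The expected step is an at least 2.2-fold lower number from compound 2 to compound 3 (0.34 log units; beyond the scatter). Compound 3 is estimated at 45000 nM, within an expected range of 18000 nM to 100000 nM.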

Compound 3, half-maximal inhibitory concentration: 13000 nM
The estimate for compound 3 lay 3.5-fold (0.54 log units) above the measured number, outside the stated range (below it).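

In this assay, pent-4-en-1-yl on the saturated chain carbon gives an at least 7.6-fold lower number from compound 2 to compound 3 (0.88 log units; beyond the scatter). Compound 2 stands at a limit of the assay and not at a number: the limit of > 100000 nM in this assay, at which 1 of the 3 values shown sits. What is new is that the make-up of the chain counts, not only its presence: vinyl in place of ethyl, four bonds along the chain from an oxygen on an aromatic ring, gives a 3.3-fold lower number from compound 1 to compound 3 (0.52 log units; beyond the scatter).

The compounds shown do not tell why this double bond lowers the number. Going by these compounds, whether a longer chain, or an amine or a carboxylic acid on the chain, would lower it further stays open.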